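The compounds below may be only part of what the source reports. "The series", "measured", "known", "first", "only" and "open" are said of these compounds alone.

Going by the values given here, in a functional assay on HeLa cells (Homo sapiens) for inhibition, read by MTT assay, with a stated time of 72 h (a lower number here means a stronger inhibitor, a higher number a weaker inhibitor), compound 1 (`C=C(Br)C(=O)Nc1cccc(/C=C/C(=O)Nc2ccc(F)c(F)c2)c1`) gives 1900 nM and compound 2 (`C=C(Br)C(=O)Nc1cccc(/C=C/C(=O)NCc2ccc(C)cc2)c1`) gives 1700 nM so compound 2 stands level with the only other measured compound. The next compound, compound 3 (`C=C(Br)C(=O)Nc1cccc(/C=C/C(=O)Nc2ccc(OC)cc2)c1`), has no number yet. It carries 4-methoxyphenyl in place of 4-methylbenzyl on an amide-type nitrogen. Among the compounds with values here, one measured step bears on this change. It swaps groups at the same place: a 1.1-fold lower number from compound 1 to compound 2 (0.05 log units; within the scatter) and it stays within the scatter. That step took 3,4-difluorophenyl out and put 4-methylbenzyl in, and compound 3 returns to a phenyl group. Within the data shown here, no measured compound has 4-methoxyphenyl, so this evidence is thin. No shift beyond the scatter is expected in this assay and the expected size is a 1.1-fold higher number from compound 2 to compound 3 (0.02 log units; within the scatter) for this change. The estimated value for compound 3 is 1800 nM (expected range 850 nM to 3800 nM).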

Compound 3, half-maximal inhibitory concentration: 790 nM
The estimate for compound 3 lay 2.3-fold (0.36 log units) above the measured number; the whole stated range lies above it.
By their numbers in this assay, from the lowest: compound 3; then compounds 2 and 1 (each within the scatter of the next).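

In this assay, the group on the amide-type nitrogen proves able to shift the number, with a 2.2-fold lower number from compound 2 to compound 3 (0.33 log units; beyond the scatter) and a 2.4-fold lower number from compound 1 to compound 3 (0.38 log units; beyond the scatter). Going by these compounds alone, both steps are modest, but they lie beyond the scatter, which the step between the 3,4-difluorophenyl and 4-methylbenzyl compounds did not, so 4-methoxyphenyl is the first group here to stand apart from the others. No measurement shown accounts for this difference.

Compared with 4-methylbenzyl, 4-methoxyphenyl both lacks the carbon link between ring and nitrogen and carries methoxy rather than methyl, so these compounds cannot separate the two changes. On these data alone, a 4-methylphenyl or 4-methoxybenzyl group on the same nitrogen would pull them apart, and whether the gain holds for another group, such as 4-ethoxyphenyl, remains open.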